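Amide in place of benzylamine on the shared core

A few compounds are considered here, and "the series" means these few. Any claim that something is new, unique, unknown or untested is made for them only; others in the source may bear on it.

Compound 1 `CCN1CCN(CCCn2cnc3c(N4CCN(C5CCCC5)CC4)nc(NCc4ccc(F)cc4)nc32)CC1`: 250 nM
Compound 2 `CCN1CCN(CCCn2cnc3c(N4CCN(C(=O)C5CCCC5)CC4)nc(NCc4ccc(F)cc4)nc32)CC1`: > 30000 nM

For the measured compounds named here, compound 1 holds the only number in an assay on HEK293 cells for antagonist activity at Toll-like receptor 9 (Homo sapiens), read by spectrophotometry; on this read-out higher numbers stand for weaker inhibition and lower numbers for stronger inhibition; compound 2 shows a limit of the assay rather than a number. That limit is the limit of > 30000 nM in this assay, at which 1 of the 2 values shown sits. Compound 3 `CCN1CCN(CCCn2cnc3c(N4CCN(C5CCCC5)CC4)nc(NC(=O)c4ccc(CN(C)C)cc4)nc32)CC1` carries (4-((dimethylamino)methyl)phenyl)carbonyl in place of 4-fluorobenzyl on a nitrogen on an aromatic ring. Going by the values given here, the one measured step bears on it by analogy: an at least 120-fold higher number from compound 1 to compound 2 (2.07 log units; beyond the scatter), where a cyclopentylcarbonyl replaced cyclopentyl on an amine nitrogen in a ring and the value went out to the limit. A carbonyl again enters on a nitrogen here, so a large loss is expected, a 24-fold higher number from compound 1 to compound 3 (1.38 log units; beyond the scatter). Compound 3 is estimated at 6000 nM, between 800 nM and 30000 nM, with a fair chance of only a limit.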

Compound 3, half-maximal inhibitory concentration: 60 nM
The estimate for compound 3 lay 100-fold (2.00 log units) above the measured number, outside the stated range (below it).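

At this place, on a nitrogen on an aromatic ring, (4-((dimethylamino)methyl)phenyl)carbonyl in place of 4-fluorobenzyl gives a 4.2-fold lower number from compound 1 to compound 3 (0.62 log units; beyond the scatter) in this assay and so is tolerated. A carbonyl on a nitrogen therefore does not cost activity here, unlike the cyclopentylcarbonyl of compound 2 on the amine nitrogen in a ring. Nothing in the data shown accounts for the gain.

On these data alone, whether the carbonyl or the dimethylaminomethyl group carries the gain stays open. A plain benzoyl group without the amine, or a benzyl group bearing the dimethylaminomethyl group, would separate the two.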